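Fluoro in place of acetamido: notes on compound 4

This account rests on a few compounds, and the source may have more. Where it says the series, first, only, none or still open, it means among the compounds named here.

For the measured compounds named here, in a functional assay on the whole organism (Tail) for activation, with Mus musculus as the target, with a stated time of 1 min (on this read-out higher numbers stand for an effect only at larger amounts of compound and lower numbers for an effect already at smaller amounts), compound 1 `O=C1NC(=O)N(/N=C/c2ccc(-c3ccc(Cl)c(Cl)c3)o2)C1O` gives 34 mg/kg, the only true number so far. Compound 2 `CC(=O)Nc1ccc(-c2ccc(/C=N/N3C(=O)NC(=O)C3O)o2)cc1` gives > 1000 mg/kg, which is a limit of the assay and not a number. Compound 3 `O=C1NC(=O)N(/N=C/c2ccc(-c3cccc(C(F)(F)F)c3)o2)C1O` gives > 1000 mg/kg, also a limit. Compound 2 therefore sits with compound 3 at the limit of > 1000 mg/kg in this assay, at which 2 of the 3 values shown sit, and no exact position can be given for it.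

Compound 4 `O=C1NC(=O)N(/N=C/c2ccc(-c3ccc(F)cc3)o2)C1O` keeps the shared core of compound 2 and carries fluoro in place of acetamido on an aromatic carbon, para to a large group: fluoro in place of acetamido on an aromatic carbon. Like compound 1, at 34 mg/kg, compound 4 has halogen directly on the aromatic ring, though a single example is weak support. A move towards effect at smaller amounts is expected, with a real chance of no number at all. Going by these compounds, the expected step is an at least 5.0-fold lower number from compound 2 to compound 4 (0.69 log units; beyond the scatter), and its true size stays open while the starting point is only a limit. For compound 4 the estimated value is 200 mg/kg, with an expected range of 30 mg/kg to 1000 mg/kg.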

Compound 4, dose for half-maximal effect: > 1000 mg/kg
Compound 4: only a limit was reported; the forecaster's own chance of this, stated with the estimate: 45%; at least 5.0-fold (0.69 log units) between middle value and limit.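

Compound 2 and compound 4 each give only a limit of the assay and not a number, so no step can be read between them: the limit of > 1000 mg/kg in this assay, at which 3 of the 4 values shown sit. The compounds shown leave open what size, if any, the change from acetamido to fluoro has on this read-out.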